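This account rests on a few compounds, and the source may have more. Where it says the series, first, only, none or still open, it means among the compounds named here.

Working notes on the series. The shared core is that of compound 2 `O=C(O)CCCCCOc1cc(-c2ccccc2)cc(-c2ccccc2)n1`. For the measured compounds named here, in a functional assay on cells for inhibition of leukotriene B4 receptor 1 (Homo sapiens) (a higher number here means a weaker inhibitor, a lower number a stronger inhibitor), compound 2 gives 2000 nM, the lowest of the two numbers so far, with compound 3 `O=C(O)CCCCCCOc1cc(-c2ccccc2)cc(-c2ccccc2)n1` nearest, which gives 2500 nM; the step of a 1.3-fold higher number from compound 2 to compound 3 (0.10 log units; within the scatter) is within the scatter. Compound 1 `O=C(O)CCCCCOc1cc(-c2ccccc2Cl)cc(-c2ccccc2)n1` sits at a limit of this assay, giving > 10000 nM; that limit is the limit of > 10000 nM in this assay, at which 1 of the 3 values shown sits. Going by the values given here, the one step that reads as beyond the scatter is an at least 5.0-fold lower number from compound 1 to compound 2 (0.69 log units; beyond the scatter).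

Compound 4 `O=C(O)CCCCCOc1cc(-c2ccc(C(F)(F)F)cc2)cc(-c2ccccc2)n1` differs from compound 2 by trifluoromethyl in place of hydrogen on an aromatic carbon. Among the compounds with values here, the only measured step touching a substituent on that same phenyl ring is the step from compound 1 to compound 2 , where removing a substituent lowered the number by an at least 5.0-fold lower number from compound 1 to compound 2 (0.69 log units; beyond the scatter); the chain step a 1.3-fold higher number from compound 2 to compound 3 (0.10 log units; within the scatter) says nothing about substitution on that ring. On this basis a substituent entering that ring is expected to raise the number in this assay, and the step of a 2.5-fold higher number from compound 2 to compound 4 (0.40 log units; beyond the scatter) is estimated as a modest rise. Compound 4 is therefore expected to give about 5000 nM, within a range of 1500 nM to 20000 nM, with a real chance that only a limit is reported.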

Compound 4, half-maximal inhibitory concentration: 10000 nM
Beside the measured number, compound 4's estimate is 2.0-fold (0.30 log units) below it; measured number inside the range.
By their numbers in this assay, from the lowest: compounds 2 and 3 (each within the scatter of the next); then compound 4.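

In this assay trifluoromethyl in place of hydrogen on an aromatic carbon, para to a large group, gives a 5.0-fold higher number from compound 2 to compound 4 (0.70 log units; beyond the scatter) and so this place is also not free for substitution. Until now, the only substituted ring in the series was the 2-chlorophenyl of compound 1; compounds 1 and 4 now both sit higher than compound 2, and no compound shown goes against this. The step of a number no higher from compound 1 to compound 4 (the limit leaves the size open) cannot be read for size. Compound 1 stands at a limit: the limit of > 10000 nM in this assay, at which 1 of the 4 values shown sits.

On these data alone, whether a fluoro, chloro or methoxy group at this same place would stay closer to compound 2 remains open. As far as these compounds go, the effect of any group on the other phenyl ring of the shared core is also open.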